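A Chloro Added to Compound 3: What to Expect

The compounds below may be only part of what the source reports. "The series", "measured", "known", "first", "only" and "open" are said of these compounds alone.

Of the compounds shown here, three have been measured in a functional assay on HCC 2998 cells (Homo sapiens) for inhibition; on this read-out lower numbers stand for stronger inhibition of growth and higher numbers for weaker inhibition of growth. Compound 1 `COc1cc(/C=C/C(=O)c2cccc(-n3cc(-c4ccc(Cl)cc4)[nH]c3=O)c2)cc(OC)c1OC` gives 2460 nM, and compound 2 `COc1cc(/C=C/C(=O)c2cccc(-n3cc(-c4ccccc4)[nH]c3=O)c2)ccc1O` gives 1510 nM. Compound 3 `O=C(/C=C/c1cccc(O)c1)c1cccc(-n2cc(-c3ccccc3)[nH]c2=O)c1` gives 4090 nM, the highest number of the three; its gap to compound 1 lies within the scatter, while the step of a 2.7-fold higher number from compound 2 to compound 3 (0.43 log units; beyond the scatter) lies beyond it. Compound 4 `O=C(/C=C/c1cccc(O)c1)c1cccc(-n2cc(-c3ccc(Cl)cc3)[nH]c2=O)c1` differs from compound 3 by chloro in place of hydrogen on an aromatic carbon. Going by the values given here, no measured step isolates this change: compounds 1 and 2 differ in the chloro but also elsewhere, so only their two numbers can be compared. Among the compounds with values here, with no step bearing on the change, no shift beyond the scatter is expected, and the step of a 1.0-fold lower number from compound 3 to compound 4 (0.01 log units; within the scatter) is estimated as essentially flat. Compound 4 is therefore expected near 4000 nM, within 1800 nM to 9000 nM.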

Compound 4, concentration for 50% growth inhibition: 13700 nM
The estimate for compound 4 lay 3.4-fold (0.53 log units) below the measured number; the whole stated range lies below it.
By their numbers in this assay, from the lowest: compounds 2, 1 and 3 (each within the scatter of the next, the first and the last beyond it); then compound 4.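

In this assay, going by these compounds alone, chloro in place of hydrogen on this aromatic carbon can be read on its own for the first time, and it is not neutral: the change from phenyl to 4-chlorophenyl gives a 3.3-fold higher number from compound 3 to compound 4 (0.52 log units; beyond the scatter) and so weaker inhibition of growth. No evidence at hand bears on this shift. Still open, on these data alone, is whether fluoro or an amine on the same aromatic carbon would move the number as chloro does, and whether chloro would act alike with the 4-hydroxy-3-methoxyphenyl group of compound 2 in place of 3-hydroxyphenyl.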